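The compounds below may be only part of what the source reports. "The series", "measured", "known", "first", "only" and "open" are said of these compounds alone.

Measured compounds:
- compound 1, `CC(NC(=O)Nc1ccc(Nc2ncnc3[nH]ncc23)cc1)c1ccccc1`: > 100000 nM
- compound 2, `Cc1cccc(NC(=O)Nc2ccc(Oc3ncnc4[nH]ncc34)cc2)c1C`: 98800 nM

In an assay on isolated protein for inhibition of vascular endothelial growth factor receptor 2 (Danio rerio), read by fluorescence and microscopy, with a stated time of 33 h (on this read-out lower numbers stand for stronger inhibition and higher numbers for weaker inhibition), compound 1 gives > 100000 nM, which is a limit of the assay and not a number. In this assay compound 2 gives 98800 nM; this is the only number shown. Among the compounds with values here, the one further value is that of compound 1, which sits at the limit of > 100000 nM in this assay, at which 1 of the 2 values shown sits. No step between measured compounds is shown, so the size of a change on the amide-type nitrogen is not known from the data.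

Compound 3, `O=C(Nc1ccc(Oc2ncnc3[nH]ncc23)cc1)NC1CCCCC1`, is to be measured in this assay. It differs from compound 2 by cyclohexyl in place of 2,3-dimethylphenyl on an amide-type nitrogen. With compound 2 standing at the edge of the measurable range, no step beyond the scatter is expected, and the step from a 1.2-fold higher number from compound 2 to compound 3 (0.08 log units; within the scatter) is an estimate only. Compound 3 is expected to give about 120000 nM, in a range from 30000 nM to 400000 nM, with a fair chance that only a limit is reported.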

Compound 3, half-maximal inhibitory concentration: > 100000 nM
Compound 3: only a limit was reported (the forecaster's own chance of this, stated with the estimate: 55%); the middle value does not contradict the limit.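

Within the data shown here, replacing 2,3-dimethylphenyl with cyclohexyl on the amide-type nitrogen gives an at least 1.0-fold higher number from compound 2 to compound 3 (0.00 log units; that floor lies within the scatter) in this assay, the first step that can be read at this position, and it is a floor rather than a measured size. Compound 3 gives > 100000 nM, which is a limit of the assay and not a number. With an aromatic ring and a non-aromatic ring both tried on this nitrogen, neither brings the series clear of the edge of the range, and this end of the read-out leaves little room to separate compounds: the limit of > 100000 nM in this assay, at which 2 of the 3 values shown sit.

As far as these compounds go, how far compound 3 lies past its limit stays open, so the true size of the step cannot be read. Also open, from the compounds shown here alone, is whether a different group on this nitrogen, such as a longer chain ending in an amine or a carboxylic acid, would give a number well inside the measurable range.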